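Thiazolidinone amides: exchanging the aryl group on the ring nitrogen

This account rests on a few compounds, and the source may have more. Where it says the series, first, only, none or still open, it means among the compounds named here.

Compound 1 `COc1ccccc1N1C(=O)C(C)SC1c1cccc(C(=O)NCCCCc2ccccc2)c1`: 82%
Compound 2 `O=C(NCCCCc1ccccc1)c1cccc(C2OCC(=O)N2c2cccc(F)c2)c1`: 29%
Compound 3 `COc1cc(F)ccc1N1C(=O)CSC1c1cccc(C(=O)NCCCCc2ccccc2)c1`: 81%

In a functional assay on HOS cells (Homo sapiens) for inhibition, read by CCK-8 assay, with a stated time of 72 h, tested at 1 uM (on this read-out higher numbers stand for more inhibition at the one concentration tested (going by the name of the read-out) and lower numbers for less inhibition), compound 3 gives 81%, the second highest of the three numbers. Its nearest neighbour is compound 1, whose value lies within the scatter of that of compound 3; compound 2 is furthest, its value lying beyond the scatter below compound 3.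

Compound 4 `O=C(NCCCCc1ccccc1)c1cccc(C2SCC(=O)N2c2ccccc2F)c1` differs from compound 3 in one place: 2-fluorophenyl in place of 4-fluoro-2-methoxyphenyl on an amide-type nitrogen in a ring. Among the measured compounds shown here, no pair of measured compounds shows this change, so its effect is not known from the data. As far as these compounds go, the values of compound 1 and compound 3 lie within the scatter of each other, so the two aryl groups on the ring nitrogen in those compounds give level numbers in this assay, but the loss of the methoxy group is untested. A modest decrease is expected, with the step from compound 3 to compound 4 estimated as a number 16 percentage points lower from compound 3 to compound 4 (beyond the scatter), not clearly beyond the scatter. Compound 4 is expected to give about 65%, with a range from 35% to 85%.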

Compound 4, a percentage reported as inhibition, at one concentration (the size of the read-out at that concentration, not a potency): 83%
Estimate against measurement, compound 4: 18 percentage points below; the range from low to high includes it.
By their numbers in this assay, from the lowest: compound 2; then compounds 3, 1 and 4 (each within the scatter of the next).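

Exchanging 4-fluoro-2-methoxyphenyl for 2-fluorophenyl on the amide-type nitrogen in the ring gives a number 2 percentage points higher from compound 3 to compound 4 (within the scatter) in this assay and so leaves the read-out level. At this position, then, the number holds without the methoxy group, and a single fluorine on the aryl group is enough to keep it. Nothing measured here gives a reason for this level result.

As far as these compounds go, whether an amine or a carboxylic acid on this aryl group would keep the number remains open. So does the effect of a longer chain on the amide.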